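A few compounds are considered here, and "the series" means these few. Any claim that something is new, unique, unknown or untested is made for them only; others in the source may bear on it.

Compound 1 `CCCCOc1ccc(/C=N/NC(N)=S)c2ccccc12` and compound 2 `NC(=S)N/N=C/c1ccc(OCc2ccccc2)c2ccccc12` are built on the same core and differ in a single place: phenyl in place of propyl on a saturated chain carbon bound to an oxygen on an aromatic ring. Both have been tested in a toxicity assay on THP-1 cells (Homo sapiens) for cytotoxicity, read by MTT assay, with a stated time of 72 h; on this read-out higher numbers stand for an effect only at larger amounts of compound and lower numbers for an effect already at smaller amounts. For compound 1, this assay gives only a limit, > 200000 nM. Compound 2 gives 27000 nM in this assay. The change thus produced an at least 7.4-fold lower number from compound 1 to compound 2 (0.86 log units; beyond the scatter).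

Compound 3 `CCCCOc1c(/C=N/NC(N)=S)ccc2ccccc12` contains the same atoms as compound 1, joined differently; the difference between the two cores is not broken down here. For compound 3, this assay again returns only a limit, > 200000 nM. Two of the three results gathered so far sit at the limit of > 200000 nM in this assay, at which 2 of the 3 values shown sit, so for these compounds the assay often does not reach a number at all.

Compound 4 `NC(=S)N/N=C/c1ccc2ccccc2c1OCc1ccccc1` has not yet been measured in this assay. It differs from compound 3 in the same way that compound 2 differs from compound 1: phenyl in place of propyl on a saturated chain carbon bound to an oxygen on an aromatic ring. Because the same change in compound 1 gave an at least 7.4-fold lower number from compound 1 to compound 2 (0.86 log units; beyond the scatter), compound 4 is expected to show an at least 5.0-fold lower number from compound 3 to compound 4 (0.69 log units; beyond the scatter). The estimate for compound 4 in this assay is 40000 nM, and the measured number is expected to fall between 15000 nM and 200000 nM. Whether this second core responds to the change in the same way as the first is what the coming measurement will show.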

Compound 4, half-maximal effective concentration: 28000 nM
The estimate for compound 4 lay 1.4-fold (0.15 log units) above the measured number; low and high end bracket the measured number.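

In this assay, the change from butoxy to benzyloxy on the core of compound 3 gives an at least 7.1-fold lower number from compound 3 to compound 4 (0.85 log units; beyond the scatter), so the drop seen on the first core appears on the second as well. Set side by side, the two steps read: the same change on two cores in this assay, an at least 7.4-fold lower number (0.86 log units; beyond the scatter) from compound 1 to compound 2 and an at least 7.1-fold lower number (0.85 log units; beyond the scatter) from compound 3 to compound 4; the limit leaves it open whether they differ Both steps start from a limit and not from a number, so the true size of each remains unknown; what carries over is the direction, on these two cores only, and nothing here shows that the two steps are equal in size or that the change would act the same way on any further core.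

The compounds shown leave open whether an aromatic ring is needed at this place at all, a question that a cyclohexyl group or a longer saturated chain on the same carbon could help to answer. Also open are how a phenyl ring carrying an amine or a carboxylic acid would read in this assay and how the butoxy compounds would compare if they gave real numbers, given how many results stop at the limit: the limit of > 200000 nM in this assay, at which 2 of the 4 values shown sit.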